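Chloromethylbenzyl chloropurines: cytotoxicity notes toward compound 4

A few compounds are considered here, and "the series" means these few. Any claim that something is new, unique, unknown or untested is made for them only; others in the source may bear on it.

Measured in a functional assay on UO-31 cells (Homo sapiens) for cytotoxicity, read by sulforhodamine B assay, with a stated time of 48 h; on this read-out higher numbers stand for lower toxicity in this test and lower numbers for higher toxicity in this test:
compound 1 `ClCc1ccccc1Cn1cnc2c(Cl)nc(Cl)nc21`: 5920 nM
compound 2 `ClCc1cccc(Cn2cnc3ncnc(Cl)c32)c1`: 26900 nM
compound 3 `ClCc1ccc(Cn2cnc3c(Cl)nc(Cl)nc32)cc1`: 66100 nM

Compound 2 holds the second highest of the three numbers in this assay; compound 3 sits above it by a gap beyond the scatter, and compound 1 sits below it by a larger gap, also beyond the scatter. Compound 4 `ClCc1cccc(Cn2cnc3nc(Cl)nc(Cl)c32)c1` differs from compound 2 by chloro in place of hydrogen on an aromatic carbon, the new chloro group placed between two ring nitrogen atoms of the core. Among the measured compounds shown here, no measured pair isolates this change, so its size in this assay is open; the two dichloro compounds bracket compound 2 on both sides. The step from compound 2 to compound 4 is expected to be a 1.7-fold lower number from compound 2 to compound 4 (0.23 log units; within the scatter), a modest move toward a lower number. Compound 4 is estimated at 16000 nM, with a range from 4500 nM to 55000 nM.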

Compound 4, concentration lethal to 50% of the cells: 72400 nM
The estimate for compound 4 lay 4.5-fold (0.66 log units) below the measured number, outside the stated range (above it).
By their numbers in this assay, from the lowest: compound 1; then compound 2; then compounds 3 and 4 (each within the scatter of the next).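

Among the compounds shown here, the step of a 2.7-fold higher number from compound 2 to compound 4 (0.43 log units; beyond the scatter) in this assay is the first change that can be read at a single place, and it runs toward lower toxicity in this test. On the core of compound 2, chloro on this carbon between two ring nitrogen atoms therefore raises the number. Nothing available explains this step.

As far as these compounds go, whether an amine, a methoxy group or a methyl group on the same carbon would move the number the same way remains open. Also open, from the compounds shown here alone, is whether the chloro step keeps its size when the chloromethyl group sits elsewhere on the benzyl ring.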